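Unsubstituted phenyl on the chalcone chain of compound 3

The compounds below may be only part of what the source reports. "The series", "measured", "known", "first", "only" and "open" are said of these compounds alone.

Two thiourea chalcones have been measured in a functional assay on the whole organism (Abdomen, strain Swiss) for inhibition, with Mus musculus as the target, with a stated time of 30 min, at a dose of 10 mg/kg by the intraperitoneal route; a lower number here means less inhibition, a higher number more inhibition at the dose given (going by the name of the read-out). Compound 1 `COc1ccc(/C=C/C(=O)c2ccc(NC(=S)Nc3ccc(Cl)cc3)cc2)cc1` gives 92% in this assay, and compound 2 `O=C(/C=C/c1ccc(Cl)c(Cl)c1)c1ccc(NC(=S)Nc2ccc(Cl)cc2)cc1` gives 97.5%. Within the data shown here, the only step between them, a number 5.5 percentage points higher from compound 1 to compound 2 (within the scatter), lies within the scatter, so compound 2 and compound 1 stand together at the top of the set without any ordered difference between them.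

Compound 3 `O=C(/C=C/c1ccccc1)c1ccc(NC(=S)Nc2ccc(Cl)cc2)cc1` is not yet measured. It differs from compound 2 by phenyl in place of 3,4-dichlorophenyl on a double-bonded chain carbon bound to a double-bonded chain carbon.

Among the measured compounds shown here, the one measured step, from compound 1 to compound 2, exchanged the aryl group in the same place and moved the read-out by a number 5.5 percentage points higher from compound 1 to compound 2 (within the scatter), a change within the scatter. On that basis, an exchange of the aryl group on a double-bonded chain carbon bound to a double-bonded chain carbon is not expected to move this assay beyond the scatter in either direction. Compound 3 is therefore expected to show about 90%, within the range 75% to 99%. The estimated step of a number 7.5 percentage points lower from compound 2 to compound 3 (within the scatter) is expected to lie within the scatter.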

Compound 3, a percentage reported as inhibition, in the whole organism at one dose (the size of the read-out at that dose, not a potency): 94.5%
The estimate for compound 3 lay 4.5 percentage points below the measured number; measured number inside the range.
By their numbers in this assay, from the lowest: compounds 1, 3 and 2 (each within the scatter of the next).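

In this assay, among these compounds, the unsubstituted phenyl on a double-bonded chain carbon bound to a double-bonded chain carbon gives a first reading without any group on that ring, and it cannot be told apart from either substituted ring: a number 3 percentage points lower from compound 2 to compound 3 (within the scatter) for phenyl in place of 3,4-dichlorophenyl, and a number 2.5 percentage points higher from compound 1 to compound 3 (within the scatter) for hydrogen in place of methoxy on an aromatic carbon. Among the compounds shown here, the earlier step compared only two substituted rings, whereas these three compounds show that neither the two chlorines nor the methoxy separates its compound from the bare phenyl at this dose, so all three compounds remain level within the scatter. Nothing available explains why these exchanges leave the read-out unresolved.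

The compounds shown leave open whether a ring carrying an amine or a carboxylic acid, or a longer chain in place of the aryl group, would hold the read-out at this position. They also leave open whether the 4-chlorophenyl on the thiourea, which all three compounds share, can be exchanged for phenyl or a methoxyphenyl without a step beyond the scatter.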